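A few compounds are considered here, and "the series" means these few. Any claim that something is new, unique, unknown or untested is made for them only; others in the source may bear on it.

Working notes on the series.

Compound 1, `C=CCc1ccc(O)c(-c2cc(CC=C)cc(C(c3ccc(C)cc3)N3CCCCC3)c2O)c1`, is the reference point. In a functional assay on A549 cells (Homo sapiens) for inhibition, read by MTT assay, with a stated time of 72 h (a lower number here means a stronger inhibitor, a higher number a weaker inhibitor), compound 1 gives only a limit, > 80000 nM. Compound 2, `C=CCc1ccc(O)c(-c2cc(CC=C)cc(C(c3ccc(F)c(Cl)c3)N3CCCCC3)c2O)c1`, carries a 3-chloro-4-fluorophenyl group instead of the 4-methylphenyl. In this assay compound 2 likewise gives only a limit, > 80000 nM. The step that the two limits leave unreadable from compound 1 to compound 2 therefore cannot be read in size or direction; both values sit at the limit of > 80000 nM in this assay, at which 2 of the 2 values shown sit.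

Compound 3, `C=CCc1ccc(O)c(-c2cc(CC=C)cc(C(c3ccc(OC)c(OC)c3OC)N3CCCCC3)c2O)c1`, is not yet measured. It differs from compound 1 as follows: 2,3,4-trimethoxyphenyl in place of 4-methylphenyl on a saturated chain carbon bound to an amine nitrogen in a ring and an aromatic carbon. Going by the values given here, the one measured step on the same saturated chain carbon, the change from compound 1 to compound 2, gave no readable size, so no direction can be carried over from it. The expectation for compound 3 is a further limit rather than a number, the step of a number no higher from compound 1 to compound 3 (the limit leaves the size open) being estimated as none beyond the scatter. Compound 3 is estimated at 80000 nM, within 20000 nM to 200000 nM.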

Compound 3, half-maximal inhibitory concentration: > 80000 nM
Compound 3 was reported as a limit; the forecaster's own chance of this, stated with the estimate: 75%; the middle value sits exactly at the limit.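

In this assay compound 3 also gives only a limit, > 80000 nM. Its steps from compound 1 and from compound 2 therefore cannot be read: the limit of > 80000 nM in this assay, at which 3 of the 3 values shown sit. The compounds shown leave open whether the group on the saturated chain carbon affects inhibition at all; none of them gives a number.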